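Hydrazide for ester at a longer chain

The source may hold more compounds than are shown below. What is called first, only, known or untested is meant among the compounds shown, and "the series" means these compounds.

Compound 1 `NNC(=O)CN1C(=O)c2ccccc2NC1c1ccccc1`: 310000 nM
Compound 2 `COC(=O)CCN1C(=O)c2ccccc2NC1c1ccccc1`: 860000 nM
Compound 3 `COC(=O)CCN1C(=O)c2ccccc2NC1c1ccc(Cl)cc1`: 720000 nM

In an assay on mitochondria for inhibition of Amine oxidase [flavin-containing] B (Bos taurus), read by fluorescence, with a stated time of 60 min (a higher number here means a weaker inhibitor, a lower number a stronger inhibitor), compound 2 gives the highest number of the three, with compound 3 within the scatter of it and compound 1 further off, as a 2.8-fold higher number from compound 1 to compound 2 (0.44 log units; beyond the scatter) shows. Compound 4 `NNC(=O)CCCN1C(=O)c2ccccc2NC1c1ccccc1` differs from compound 2 in one place: (aminocarbamoyl)methyl in place of methoxycarbonyl on a saturated chain carbon, two bonds along the chain from an amide-type nitrogen in a ring. Among the compounds with values here, the only step that bears on this is the one from compound 1 to compound 2, which exchanged a hydrazide for an ester on a shorter chain and gave a modest rise. Running that exchange the other way on the longer chain, one expects a modest fall in this assay, a 2.2-fold lower number from compound 2 to compound 4 (0.33 log units; beyond the scatter), though the extra chain length is untested here. Compound 4 is therefore estimated at 400000 nM, with a range from 150000 nM to 1000000 nM.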

Compound 4, half-maximal inhibitory concentration: 370000 nM
Compound 4: the middle estimate sits 1.1-fold (0.03 log units) above what was measured; low and high end bracket the measured number.
By their numbers in this assay, from the lowest: compounds 1, 4, 3 and 2 (each within the scatter of the next, the first and the last beyond it).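

In this assay, the hydrazide gives a lower number than the ester on the longer chain as well (a 2.3-fold lower number from compound 2 to compound 4 (0.37 log units; beyond the scatter)), a step not read at fixed chain length before. Lengthening the hydrazide chain leaves the number within the scatter (a 1.2-fold higher number from compound 1 to compound 4 (0.08 log units; within the scatter)), so at this position the length from (aminocarbamoyl)methyl's shorter analogue to 3-(aminocarbamoyl)propyl matters little. No measurement offered here accounts for the gap between hydrazide and ester. As far as these compounds go, it remains open whether a carboxylic acid or a primary amide at the chain end would match the hydrazide. Whether a still longer chain would hold the number is also unanswered.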